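Selenium for sulfur: one swap measured, one awaiting measurement

A few compounds are considered here, and "the series" means these few. Any claim that something is new, unique, unknown or untested is made for them only; others in the source may bear on it.

Compound 1 `C[Se]c1nc(NCc2ccccc2)c2ccccc2n1` was tested in an ADME assay on 184B5 cells (Homo sapiens) for cytotoxicity, read by MTT assay, with a stated time of 72 h (a higher number here means a weaker inhibitor of growth, a lower number a stronger inhibitor of growth), where compound 1 gives 12400 nM. Compound 2 `CSc1nc(NCc2ccccc2)c2ccccc2n1` carries methylsulfanyl at the same place. In this assay compound 2 gives > 100000 nM, which is a limit of the assay and not a number. Compound 3 `CSc1ccc(CNc2nc(SC)nc3ccccc23)cc1` differs from compound 2 in one respect: methylsulfanyl in place of hydrogen on an aromatic carbon. In this assay compound 3 gives > 100000 nM, again a limit rather than a number. The step that the two limits leave unreadable from compound 2 to compound 3 therefore cannot be read. Among the compounds with values here, the one readable step is an at least 8.0-fold lower number from compound 2 to compound 1 (0.90 log units; beyond the scatter), and the structural change behind it is a group of 2 heavy atoms (1 carbon, 1 selenium; no ring) in place of a group of 2 heavy atoms (1 carbon, 1 sulfur; no ring), on an aromatic carbon. Two of the three values rest at the limit of > 100000 nM in this assay, at which 2 of the 3 values shown sit, so compound 3 stands only at a limit.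

Compound 4 `CSc1ccc(CNc2nc([Se]C)nc3ccccc23)cc1` has not yet been measured. It differs from compound 3 in one place: a group of 2 heavy atoms (1 carbon, 1 selenium; no ring) in place of a group of 2 heavy atoms (1 carbon, 1 sulfur; no ring), on an aromatic carbon. Within the data shown here, this is the same kind of change as the one from compound 2 to compound 1, made on the same aromatic carbon of the shared core. Because an at least 8.0-fold lower number from compound 2 to compound 1 (0.90 log units; beyond the scatter) moved the value off the limit, a step of similar direction is expected, an at least 6.6-fold lower number from compound 3 to compound 4 (0.82 log units; beyond the scatter), and compound 4 is estimated at 15000 nM, with a likely range from 5000 nM to 60000 nM.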

Compound 4, concentration for total growth inhibition: > 100000 nM
Compound 4 gave a limit, no number (the forecaster's own chance of this, stated with the estimate: 25%); at least 6.6-fold (0.82 log units) between middle value and limit.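

In this assay compound 4 gives > 100000 nM as a limit of the assay and not a number. With limits at both ends, the swap of methylsulfanyl for the selenium-bearing group on this core cannot be read; what can be read is an at least 8.0-fold higher number from compound 1 to compound 4 (0.90 log units; beyond the scatter) with methylsulfanyl in place of hydrogen on an aromatic carbon. Within the data shown here, the swap that gave an at least 8.0-fold lower number from compound 2 to compound 1 (0.90 log units; beyond the scatter) did not yield a number on the core of compound 3, yet this does not show that it does nothing there, only that any change stays out of the assay's reach, and the series now rests mostly on one ceiling: the limit of > 100000 nM in this assay, at which 3 of the 4 values shown sit.

Only compound 1 gives a number, so the shown compounds cannot tell how far the selenium-bearing compounds tolerate a group on that aromatic carbon, or whether a smaller one such as fluorine, or an amine or a carboxylic acid, would keep a measurable value. Also open, as far as these compounds go, is whether a longer chain than methyl on the selenium, such as ethyl or propyl, would shift the value on either core.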